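The source may report more compounds than this note shows. Statements on the series, on what has been measured and on what is new or still open speak of the compounds shown alone.

Working notes on the series. The core of compound 1 (`Oc1ccc(-c2ccc(-c3cc(O)cc(O)c3)cc2)cc1`) carries neither side chain nor hydroxamic acid. In a functional assay on K562 cells (Homo sapiens) for activation, read by flow cytometry and annexin V staining (a lower number here means that less compound is needed, a higher number that more compound is needed for the effect), compound 1 gives > 50000 nM as a limit of the assay and not a number. For the measured compounds named here, compound 2 (`O=C(CCCCCCNC(=O)c1ccc(-c2ccc(-c3cc(O)cc(O)c3)cc2)cc1)NO`) reads 16000 nM in this assay and is so far the only compound with an actual number. Compound 3 (`O=C(NO)c1ccc(-c2ccc(-c3cc(O)cc(O)c3)cc2)cc1`) is still unmeasured. The change from compound 2 to compound 3 is hydroxy in place of 6-(hydroxycarbamoyl)hexyl on an amide-type nitrogen and amounts to hydroxy in place of 6-(hydroxycarbamoyl)hexyl on an amide-type nitrogen. Going by the values given here, no measured step shows the size of this change, so the expectation rests on compound 2 at 16000 nM alone. A small rise in the concentration needed is expected, estimated as a 1.9-fold higher number from compound 2 to compound 3 (0.27 log units; within the scatter) and close to the usual scatter. For compound 3 the estimate is 30000 nM with an expected range of 12000 nM to 60000 nM in this assay once measured.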

Compound 3, concentration for half-maximal activity: > 50000 nM
Compound 3: a limit, no number; the forecaster's own chance of this, stated with the estimate: 35%; at least 1.6-fold (0.22 log units) between middle value and limit.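

In this assay, for the compounds shown here, hydroxy in place of 6-(hydroxycarbamoyl)hexyl on the amide-type nitrogen gives an at least 3.1-fold higher number from compound 2 to compound 3 (0.49 log units; beyond the scatter), the first readable step and one beyond the scatter. A hydroxycarbamoyl group on the core without the chain therefore does not reach a number here, so the presence of hydroxycarbamoyl alone does not account for the reading of compound 2. The size of this step is only a lower bound and the step between the other two compounds cannot be read, since compound 3 ends at a limit and not a number: the limit of > 50000 nM in this assay, at which 2 of the 3 values shown sit.

On these data alone, whether a shorter or longer chain on the same nitrogen would lower or raise the concentration needed remains open. So does whether the hydroxycarbamoyl end of the chain matters, which a carboxylic acid or an amine in its place would test.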